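Low Cytotoxicity in Two Compounds and an Untested Third

This account rests on a few compounds, and the source may have more. Where it says the series, first, only, none or still open, it means among the compounds named here.

Compound 1 `CSc1cccc(C(=O)N2CCCC(C(=O)Nc3ccc(Cl)cc3)C2)c1` and compound 2 `O=C(Nc1cccc(OCCc2ccccn2)c1)C1CCCN(C(=O)c2cc(C(F)(F)F)cc(C(F)(F)F)c2)C1` share a common core and were both examined in an ADME assay on PC-3 cells (Homo sapiens) for cytotoxicity, read by WST assay, tested at 100 uM; a lower number here means less inhibition, a higher number more inhibition at the concentration tested (going by the name of the read-out). In this assay compound 1 gives 0%. In this assay compound 2 gives 5%, the higher of the two numbers, yet its gap to compound 1 lies within the usual scatter, so the two compounds cannot be ranked against each other.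

Compound 3 `CC(C)(C)OC(=O)c1cccc(NC(=O)C2CCCN(C(=O)c3cc(C(F)(F)F)cc(C(F)(F)F)c3)C2)c1` has not yet been measured. It differs from compound 2 in one place: tert-butoxycarbonyl in place of 2-(pyridin-2-yl)ethoxy on an aromatic carbon. Among the measured compounds shown here, no step between two measured compounds is available to guide the expectation. Both measured numbers sit near the bottom of the scale, and the step in this assay a number 1 percentage points lower from compound 2 to compound 3 (within the scatter) is therefore expected to be small, none beyond the scatter. Compound 3 is estimated at 4%, with a range from -8% to 20%.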

Compound 3, a percentage reported as inhibition, at one concentration (the size of the read-out at that concentration, not a potency): 0%
The estimate for compound 3 lay 4 percentage points above the measured number; the range from low to high includes it.
By their numbers in this assay, from the lowest: compounds 1, 3 and 2 (each within the scatter of the next).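

In this assay, tert-butoxycarbonyl in place of 2-(pyridin-2-yl)ethoxy on an aromatic carbon gives a number 5 percentage points lower from compound 2 to compound 3 (within the scatter). Among the compounds shown here, this is the first step read at this position, and it shows that a group with no ring and one with a six-membered aromatic ring holding a hetero atom cannot be told apart here, so the exchange of the ring for the group without one leaves no step beyond the scatter. Nothing measured on these compounds bears on this result.

The compounds shown leave open whether a carboxylic acid or an amine on this aromatic carbon would give a step beyond the scatter in this assay. They also leave open whether the same exchange would read alike with a different group on the other side of the shared core.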